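This account rests on a few compounds, and the source may have more. Where it says the series, first, only, none or still open, it means among the compounds named here.

Compound 1, `Cn1c(-c2ccccc2)cnc1NC(=O)c1ccccc1`, is tested in a toxicity assay on THP-1 cells (Homo sapiens) for inhibition (a lower number here means that less compound is tolerated, a higher number that more compound is tolerated), where compound 1 gives > 100000 nM, which is a limit of the assay rather than a number. Its two companions in the set are built on the same core. Compound 2, `COc1ccc(C(=O)Nc2ncc(-c3ccc(OC)cc3)n2C)cc1`, gives > 100000 nM in this assay, again a limit. Compound 3, `COc1ccc(-c2cnc(NC(=O)c3ccccc3)n2C)cc1`, gives > 100000 nM in this assay, also a limit. The two steps that join these compounds, a step that the two limits leave unreadable from compound 1 to compound 3 and a step that the two limits leave unreadable from compound 2 to compound 3, therefore cannot be sized in either direction. What the measured set does show is the limit of > 100000 nM in this assay, at which 3 of the 3 values shown sit, so no measured change to the core has yet lowered the tolerated concentration into the readable range.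

Compound 4, `Cn1c(-c2ccccc2)cnc1NC(=O)c1ccc(Br)cc1`, differs from compound 1 by bromo in place of hydrogen on an aromatic carbon. Within the data shown here, no measured step bears on this change, since none of the recorded steps places a bromo on any ring. With every measured value sitting at the same limit, compound 4 is expected to behave in the same way, and the step from compound 1 to compound 4 is estimated as a number no higher from compound 1 to compound 4 (the limit leaves the size open). Compound 4 is therefore expected to give about 100000 nM in this assay, within a range of 30000 nM to 300000 nM.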

Compound 4, half-maximal cytotoxic concentration: > 100000 nM
Compound 4: only a limit was reported (the forecaster's own chance of this, stated with the estimate: 75%); the middle value sits exactly at the limit.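

In this assay compound 4 gives > 100000 nM, which is a limit. Among these compounds, with compound 1 and compound 4 both standing at a limit, no step between them can be read. The compounds shown leave open which change to the shared core, if any, would bring the tolerated concentration into the readable range, and all that they show is this: the limit of > 100000 nM in this assay, at which 4 of the 4 values shown sit.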